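The source may hold more compounds than are shown below. What is called first, only, known or untested is meant among the compounds shown, and "the series" means these compounds.

Among the compounds with values here, compound 2 `COc1ccc(-c2c(C)nc3c(N4CC[C@@H](NS(=O)(=O)c5ccc(Cl)cc5)C4)cc(C)nn23)cc1OC` is one of two compounds measured in an ADME assay on microsomes from liver (Mus musculus) for metabolic stability, read by LC-MS, with NADPH named in the record, with a stated time of 60 min, tested at 1 uM, in the absence of a further agent; a lower number here means that less of the compound is left, a higher number that more of the compound is left. In this assay compound 2 gives > 95%, which is a limit of the assay and not a number. Compound 1 `COc1ccc(-c2c(C)nc3c(N4CC[C@@H](NC(=O)NC(C)C)C4)cc(C)nn23)cc1OC` in this assay gives > 95%, likewise a limit. The step that the two limits leave unreadable from compound 1 to compound 2 is therefore unreadable in size, as the limit of > 95% in this assay, at which 2 of the 2 values shown sit, shows. Compound 3 `COc1ccc(-c2c(C)nc3c(N4CC[C@@H](OC(C)=O)C4)cc(C)nn23)cc1OC` differs from compound 2 by acetoxy in place of ((4-chlorophenyl)sulfonyl)amino on a saturated ring carbon. Within the data shown here, no measured step speaks to this change, so no direction can be drawn from the earlier pair. Compound 3 is estimated to give 75% (35% to 95%), an expected step of a number at least 20 percentage points lower from compound 2 to compound 3 (beyond the scatter).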

Compound 3, percent of the compound remaining: > 95%
Compound 3 ended at the assay's limit; the forecaster's own chance of this, stated with the estimate: 30%; middle value at least 20 percentage points from the limit.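

No new step can be read among compound 1, compound 2 and compound 3 in this assay, as all three stand at one limit of the assay and not at a number: the limit of > 95% in this assay, at which 3 of the 3 values shown sit. Going by these compounds, whether (isopropylcarbamoyl)amino, ((4-chlorophenyl)sulfonyl)amino and acetoxy differ at all in this assay stays open.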